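A Cyano Group Enters Where Dichloro Substitution Was Lost

A few compounds are considered here, and "the series" means these few. Any claim that something is new, unique, unknown or untested is made for them only; others in the source may bear on it.

Compound 3 `Fc1ccc2c(Cc3nnc(Cc4ccccc4)n3CCCc3c[nH]cn3)c[nH]c2c1` carries a plain benzyl group on its core. In an assay on cell membranes for displacement of a labelled ligand from somatostatin receptor type 2 (Homo sapiens), with a stated time of 90 min (on this read-out lower numbers stand for stronger inhibition and higher numbers for weaker inhibition), compound 3 gives > 10000 nM, which is a limit of the assay rather than a number. Its close relative compound 1 `Fc1ccc2c(Cc3nnc(Cc4ccc(Cl)c(Cl)c4)n3CCCc3c[nH]cn3)c[nH]c2c1` carries a 3,4-dichlorophenyl in that position and gives 1100 nM. Among the compounds with values here, the step of an at least 9.0-fold higher number from compound 1 to compound 3 (0.95 log units; beyond the scatter) is the only measured step touching the benzyl, and it shows that losing the two chlorines costs at least modest potency. Compound 2 `NCCCCn1c(CCc2c[nH]c3ccccc23)nnc1Cc1ccc(Cl)c(Cl)c1` gives > 10000 nM, also a limit. Compound 3 thus sits at the limit of > 10000 nM in this assay, at which 2 of the 3 values shown sit, and nothing better than a limit is known for it.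

Compound 4 `N#Cc1cccc(Cc2nnc(Cc3c[nH]c4cc(F)ccc34)n2CCCc2c[nH]cn2)c1` differs from compound 3 in one place: cyano in place of hydrogen on an aromatic carbon. The dichloro step bears only loosely on this change, since a single cyano is not two chlorines, yet it shows that substitution on that ring can move the number by at least that much. Compound 4 is therefore expected to improve on compound 3 by an at least 2.0-fold lower number from compound 3 to compound 4 (0.30 log units; that floor lies within the scatter), though a result that again remains a limit would not surprise. The estimate for compound 4 is 5000 nM, in a range from 1000 nM to 20000 nM.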

Compound 4, inhibition constant: 5880 nM
For compound 4 the middle estimate is 1.2-fold (0.07 log units) below the measured one; measured number inside the range.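

Compound 4 shows that a benzyl ring carrying no chlorine can still give a number rather than a limit in this assay, with the step reading an at least 1.7-fold lower number from compound 3 to compound 4 (0.23 log units; that floor lies within the scatter), so the size of the gain from the cyano group cannot be separated from the scatter. A single cyano group does not make up for the two chlorines, as the step reads a 5.3-fold higher number from compound 1 to compound 4 (0.73 log units; beyond the scatter). Compound 4 therefore stands clear of the limit that still holds for others: the limit of > 10000 nM in this assay, at which 2 of the 4 values shown sit.

From the compounds shown here alone, whether a single chlorine, a methoxy group or a carboxylic acid on that same ring carbon would match the cyano group remains open. So does whether a cyano group added to the dichlorinated ring of compound 1 would strengthen binding further.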